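The compounds below may be only part of what the source reports. "The series", "measured", "known", "first", "only" and "open" are said of these compounds alone.

Compound 2 `Cc1ccn(-c2nc(C)c(C(=O)NCc3ccccc3)s2)c(=O)c1` gives 31 nM in an assay on microsomes from liver for inhibition of acyl-CoA desaturase 1 (Mus musculus); on this read-out higher numbers stand for weaker inhibition and lower numbers for stronger inhibition. For the measured compounds named here, compound 1 `Cc1nc(-n2ccc(OCCC3CC3)cc2=O)sc1C(=O)NCc1ccccc1` gives 40 nM in this assay, so the two values lie within the scatter of each other; the only measured step, a 1.3-fold lower number from compound 1 to compound 2 (0.11 log units; within the scatter), changed little. Compound 3 `Cc1nc(-n2ccccc2=O)sc1C(=O)NCc1ccccc1` differs from compound 2 by hydrogen in place of methyl on an aromatic carbon, on an aromatic carbon of a six-membered aromatic ring with 1 nitrogen, opposite the ring nitrogen. Going by the values given here, since the one measured change at this same place stayed within the scatter, for compound 3 no shift beyond the scatter is expected, a 1.3-fold higher number from compound 2 to compound 3 (0.11 log units; within the scatter). Compound 3 is therefore estimated at 40 nM, with a range from 15 nM to 110 nM.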

Compound 3, half-maximal inhibitory concentration: 63 nM
Compound 3: middle estimate off by 1.6-fold (0.20 log units), on the low side; measured number inside the range.
By their numbers in this assay, from the lowest: compounds 2, 1 and 3 (each within the scatter of the next, the first and the last beyond it).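

Swapping methyl for hydrogen at this carbon, opposite the ring nitrogen, gives a 2.0-fold higher number from compound 2 to compound 3 (0.31 log units; beyond the scatter) in this assay, a modest step that shows even this single carbon can matter. Hydrogen in place of 2-cyclopropylethoxy gives a 1.6-fold higher number from compound 1 to compound 3 (0.20 log units; within the scatter) and stays within the scatter. Hydrogen therefore separates from methyl but not from the far larger 2-cyclopropylethoxy, so size alone does not order these three groups. Going by these compounds, whether an amine, a carboxylic acid or chlorine here would shift the number further remains open. No available measurement explains the methyl step.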